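The compounds below may be only part of what the source reports. "The series", "measured", "known", "first", "only" and "open" are said of these compounds alone.

Within the data shown here, compound 3 `CCCn1c(=O)[nH]c2nc(-c3ccc(S(=O)(=O)N4CCN(c5ccccc5F)CC4)cc3)[nH]c2c1=O` stands highest of the three numbers so far in an assay on CHO cells for displacement of a labelled ligand from adenosine receptor A2b (Homo sapiens), read by scintillation counting, with a stated time of 75 min, in the presence of a further agent that is not named here; on this read-out lower numbers stand for stronger inhibition and higher numbers for weaker inhibition; in that assay compound 3 gives 3.22 nM. Compound 1 `CCCn1c(=O)[nH]c2nc(-c3ccc(S(=O)(=O)N4CCN(Cc5cccc(C)c5)CC4)cc3)[nH]c2c1=O` gives 0.397 nM in this assay, and compound 2 `CCCn1c(=O)[nH]c2nc(-c3ccc(S(=O)(=O)N4CCN(c5ccccc5Br)CC4)cc3)[nH]c2c1=O` gives 0.137 nM. Two measured steps lead to compound 3: the step of an 8.1-fold higher number from compound 1 to compound 3 (0.91 log units; beyond the scatter), in which a 2-fluorophenyl group replaces a 3-methylbenzyl group on the ring nitrogen, and the step of a 24-fold higher number from compound 2 to compound 3 (1.37 log units; beyond the scatter), in which only the halogen on the aromatic carbon is exchanged. The remaining step, a 2.9-fold lower number from compound 1 to compound 2 (0.46 log units; beyond the scatter), shows that compound 2 and compound 1 lie on the stronger side of compound 3 by a wide margin.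

Compound 4 `CCCn1c(=O)[nH]c2nc(-c3ccc(S(=O)(=O)N4CCN(C(C)c5ccccc5)CC4)cc3)[nH]c2c1=O` differs from compound 3 by 1-phenylethyl in place of 2-fluorophenyl on an amine nitrogen in a ring. This change resembles a reversal of the step from compound 1 to compound 3, since 1-phenylethyl, like 3-methylbenzyl, carries its aromatic ring on a saturated carbon rather than directly on the ring nitrogen. Because the step of an 8.1-fold higher number from compound 1 to compound 3 (0.91 log units; beyond the scatter) was modest but well beyond the scatter, a return toward the number of compound 1 is expected, so compound 4 is expected to show a clearly lower number. The step of a 6.4-fold lower number from compound 3 to compound 4 (0.81 log units; beyond the scatter) is the expected size of that move. In this assay compound 4 is therefore estimated at 0.5 nM, with a range from 0.15 nM to 2 nM.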

Compound 4, inhibition constant: 8.34 nM
Compound 4: middle estimate off by 17-fold (1.22 log units), on the low side; measured number outside the range, above it.
By their numbers in this assay, from the lowest: compound 2; then compound 1; then compound 3; then compound 4.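

In this assay, placing the aromatic ring on a saturated carbon does not by itself give a low number at this position on the ring nitrogen: a 21-fold higher number from compound 1 to compound 4 (1.32 log units; beyond the scatter) separates 3-methylbenzyl from 1-phenylethyl, two groups of that kind. Compound 4 now has the highest number of the four, with its steps to all the others beyond the scatter: a 2.6-fold higher number from compound 3 to compound 4 (0.41 log units; beyond the scatter) places 1-phenylethyl above even 2-fluorophenyl, and a 61-fold higher number from compound 2 to compound 4 (1.78 log units; beyond the scatter) against 2-bromophenyl is the largest step in the set. No measurement offered here accounts for these differences.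

The compounds shown leave open whether the gap between 3-methylbenzyl and 1-phenylethyl follows the methyl on the aromatic ring or the methyl on the linking carbon, and a plain benzyl group on the same ring nitrogen would separate those two changes. They also leave open where a 2-chlorophenyl group would fall relative to the 2-bromophenyl and 2-fluorophenyl groups, whose compounds already differ widely in this assay.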